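Fluoro for methyl on the benzoyl arm of compound 1

A few compounds are considered here, and "the series" means these few. Any claim that something is new, unique, unknown or untested is made for them only; others in the source may bear on it.

Among the measured compounds shown here, compound 1 `Cc1ccc(C(=O)N2NC(=O)/C(=C\c3ccc(O)cc3)N=C2c2ccccc2)cc1` gives 300 mg/kg in a functional assay on the whole organism (strain albino) with Mus musculus as the target, with a stated time of 4 h (on this read-out higher numbers stand for an effect only at larger amounts of compound and lower numbers for an effect already at smaller amounts), and stands highest of the three numbers measured so far. Compound 2 `Cc1ccc(/C=C2/N=C(c3ccccc3)N(C(=O)c3ccc(C)cc3)NC2=O)cc1` gives 30 mg/kg in this assay, and compound 3 `COc1ccc(/C=C2/N=C(c3ccccc3)N(C(=O)c3ccc(C)cc3)NC2=O)cc1` gives 30 mg/kg. The steps measured within the series are a 10-fold lower number from compound 1 to compound 2 (1.00 log units; beyond the scatter), a 10-fold lower number from compound 1 to compound 3 (1.00 log units; beyond the scatter) and no change at the digits printed from compound 2 to compound 3 (within the scatter); all three concern the substituent on the arylidene ring and leave the benzoyl arm untouched.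

Compound 4 `O=C1NN(C(=O)c2ccc(F)cc2)C(c2ccccc2)=N/C1=C/c1ccc(O)cc1` differs from compound 1 by fluoro in place of methyl on an aromatic carbon. For the measured compounds named here, no measured step touches this position, so the only guidance is that compound 1 itself was measured and that the one change seen elsewhere in the molecule moved the number by a 10-fold lower number from compound 1 to compound 2 (1.00 log units; beyond the scatter). A swap of one small group for another small group on the benzoyl arm, with nothing in the series speaking for or against it, is expected to leave compound 4 within the scatter of compound 1, with the step of no change at the digits printed from compound 1 to compound 4 (within the scatter) expected to be small. The estimate for compound 4 in this assay is 300 mg/kg, with a range from 100 mg/kg to 900 mg/kg.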

Compound 4, dose for half-maximal effect: "not active" (no number reported)
Compound 4: no number reported; no gap can be computed for the estimate.
By their numbers in this assay, from the lowest: compounds 2 and 3 (each within the scatter of the next); then compound 1.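

Among the compounds shown here, compound 4 is reported as "not active" with no number in this assay, so no step from compound 1 to compound 4 can be read. Nothing shown bears on the reason for this result. The compounds shown leave open how 4-fluorophenyl compares numerically with 4-methylphenyl on the benzoyl arm.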